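The compounds below may be only part of what the source reports. "The series", "measured", "known", "first", "only" and "open" are said of these compounds alone.

Measured in a functional assay on MCF7 cells (Homo sapiens) for cytotoxicity, read by MTT assay, with a stated time of 48 h; a higher number here means a weaker inhibitor, a lower number a stronger inhibitor:
compound 1 `C/C(=N/NC(=S)Nc1ccccc1I)c1ccccn1`: 4.1 nM
compound 2 `CC(=NNC(=S)Nc1cccc(I)c1)c1ccccn1`: 45 nM
compound 3 `C/C(=N\NC(=S)Nc1cccc(I)c1)c1ccccn1`: 45 nM

In this assay compound 3 sits level with compound 2, the two together giving the highest numbers of the three, while compound 1 stands well apart with the lowest number of the set. Compound 4 `C/C(=N\NC(=S)Nc1cccc([N+](=O)[O-])c1)c1ccccn1` differs from compound 3 by nitro in place of iodo on an aromatic carbon. For the measured compounds named here, the only measured single-point step, no change at the digits printed from compound 2 to compound 3 (within the scatter), rests on the fact that one of compounds 2 and 3 is drawn with a defined configuration and the other without, at the place where they differ and involves no exchange of substituents, so no measured step bears on the change to compound 4. For compound 4 the expected step is therefore a 1.1-fold higher number from compound 3 to compound 4 (0.05 log units; within the scatter), none beyond the scatter, carried with wide uncertainty. Compound 4 is estimated at 50 nM, between 8 nM and 300 nM.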

Compound 4, half-maximal inhibitory concentration: 38 nM
Compound 4: middle estimate off by 1.3-fold (0.12 log units), on the high side; low and high end bracket the measured number.
By their numbers in this assay, from the lowest: compound 1; then compounds 4, 2 and 3 (each within the scatter of the next).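

In this assay, for the compounds shown here, the first substituent exchange gives a 1.2-fold lower number from compound 3 to compound 4 (0.07 log units; within the scatter) and so does not separate nitro from iodo at this place, meta to a large group. The two groups differ in size, with 3 heavy atoms and 2 hydrogen-bond acceptors entering against 1 heavy atom and no acceptors leaving, yet the number holds. Nothing on record explains this step.

As far as these compounds go, whether an amine, a carboxylic acid or a methoxy group at the same carbon would hold the number stays open. Also open, from the compounds shown here alone, is how nitro would read at the place where compound 1 carries its iodo.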